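The source may hold more compounds than are shown below. What is called first, only, known or untested is meant among the compounds shown, and "the series" means these compounds.

Measured so far:
- compound 1, `O=C1CCC(=O)N1C[C@H]1CN(c2ccc(-n3cc(-c4ccccn4)cn3)c(F)c2)C(=O)O1`, in an ADME assay on HEK293-A cells (Homo sapiens) for cytotoxicity, read by MTT assay, with a stated time of 48 h; on this read-out higher numbers stand for weaker inhibition and lower numbers for stronger inhibition: > 400 ug/mL
- compound 2, `O=C1CSC(=O)N1C[C@H]1CN(c2ccc(-n3cc(-c4ccccn4)cn3)c(F)c2)C(=O)O1`: 283 ug/mL
- compound 3, `COC[C@H]1CN(c2ccc(-n3cc(-c4ccccn4)cn3)c(F)c2)C(=O)O1`: > 400 ug/mL

The value of compound 1 in this assay is a limit of the assay, not a number. Compound 2 gives 283 ug/mL. The value of compound 3 is likewise a limit and not a number, so compound 3 stands at the top of what this assay can report, as described by the limit of > 400 ug/mL in this assay, at which 2 of the 3 values shown sit. Among the measured compounds shown here, the step of an at least 1.4-fold higher number from compound 2 to compound 3 (0.15 log units; that floor lies within the scatter) is the only readable one touching compound 3; the step that the two limits leave unreadable from compound 1 to compound 3 cannot be sized, since both ends are limits.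

Compound 4 is `COC(=O)NC[C@H]1CN(c2ccc(-n3cc(-c4ccccn4)cn3)c(F)c2)C(=O)O1`. It differs from compound 3 by (methoxycarbonyl)amino in place of methoxy on a saturated chain carbon bound to a saturated ring carbon. All the measured changes at this same place, moving between cyclic imide groups and a methoxy group, gave steps no larger than the scatter, so the step of a number no higher from compound 3 to compound 4 (the limit leaves the size open) is expected to be none beyond the scatter. Compound 4 is therefore expected to give 400 ug/mL, with a range from 250 ug/mL to 400 ug/mL, most likely again reported only as a limit.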

Compound 4, half-maximal inhibitory concentration: 306 ug/mL
Beside the measured number, compound 4's estimate is 1.3-fold (0.12 log units) above it; measured number inside the range.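

Among the compounds shown here, compound 4 carries the first group at this position with a hydrogen-bond donor, and in this assay it gives a readable number rather than a limit. Against compound 2 the change is a 1.1-fold higher number from compound 2 to compound 4 (0.03 log units; within the scatter) and so the open-chain (methoxycarbonyl)amino and the cyclic 2,4-dioxo-1,3-thiazolidin-3-yl cannot be told apart here. Two comparisons give only floors, namely an at least 1.3-fold lower number from compound 3 to compound 4 (0.11 log units; that floor lies within the scatter) and an at least 1.3-fold lower number from compound 1 to compound 4 (0.11 log units; that floor lies within the scatter) and no true size, since compounds 1 and 3 each end at a limit, not a number: the limit of > 400 ug/mL in this assay, at which 2 of the 4 values shown sit.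

As far as these compounds go, how far compounds 1 and 3 lie past that limit stays open. Also open, from the compounds shown here alone, is whether an amine, a carboxylic acid or a longer chain on this same saturated chain carbon would move the number beyond the scatter.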